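Thiophene attachment point swap in a silent pair

The compounds below may be only part of what the source reports. "The series", "measured", "known", "first", "only" and "open" are said of these compounds alone.

Measured so far:
compound 1 `CC(=O)Oc1cccc2cc(-c3cccs3)c(=O)oc12`: > 100000 nM
compound 2 `CC(=O)Oc1ccc2cc(-c3cccs3)c(=O)oc2c1OC(C)=O`: > 100000 nM

In an assay on CHO cells for displacement of a labelled ligand from adenosine receptor A1 (Homo sapiens) (on this read-out lower numbers stand for stronger inhibition and higher numbers for weaker inhibition), compound 1 gives > 100000 nM, which is a limit and not a number. Compound 2, with acetoxy in place of hydrogen on an aromatic carbon, gives > 100000 nM in this assay, again a limit. Among the measured compounds shown here, the one measured step, a step that the two limits leave unreadable from compound 1 to compound 2, is therefore not readable in size or direction; all that is known is the limit of > 100000 nM in this assay, at which 2 of the 2 values shown sit. Compound 1 thus stands at the limit itself, with no numerical value anywhere in the series to place it against.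

Compound 3 `CC(=O)Oc1cccc2cc(-c3ccsc3)c(=O)oc12` differs from compound 1 by thiophen-3-yl in place of thiophen-2-yl on an aromatic carbon. For the measured compounds named here, no measured step touches the thiophenyl group, so nothing says how this change moves the inhibition constant. Going by the values given here, with compound 1 at the limit and the only neighbouring step unreadable, compound 3 is expected to remain at or near the limit as well, a step of a number no higher from compound 1 to compound 3 (the limit leaves the size open). The estimate for compound 3 is 100000 nM, with a range from 30000 nM to 300000 nM.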

Compound 3, inhibition constant: > 100000 nM
Compound 3: no number, only a limit (the forecaster's own chance of this, stated with the estimate: 85%); the middle value sits exactly at the limit.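

In this assay compound 1 and compound 3 both give only a limit, so the step from thiophen-2-yl to thiophen-3-yl cannot be read in size or direction. The compounds shown leave open which change on the shared core, if any, gives a readable inhibition constant, with all of them at one limit: the limit of > 100000 nM in this assay, at which 3 of the 3 values shown sit.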